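From compound 2 to compound 3: losing the methyl

This account rests on a few compounds, and the source may have more. Where it says the series, first, only, none or still open, it means among the compounds named here.

In a physicochemical assay for metabolic stability, read by HPLC, in phosphate buffer, at pH 7.4, tested at 10 uM (a lower number here means that the compound disappears faster, a higher number that the compound lasts longer), compound 1 `Cc1ccccc1CNC(=O)n1c(N)nc2ccccc21` gives 0.167 h and compound 2 `Cc1cccc(CNC(=O)n2c(N)nc3ccccc32)c1` gives 0.183 h. Among the compounds with values here, these are the only two numbers so far, and they lie within the scatter of each other, so compound 2 cannot be separated from compound 1, its nearest neighbour.

Compound 3 `Nc1nc2ccccc2n1C(=O)NCc1ccccc1` differs from compound 2 as follows: hydrogen in place of methyl on an aromatic carbon. This is hydrogen in place of methyl on an aromatic carbon, which turns 3-methylphenyl into phenyl.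

Within the data shown here, only one measured step bears on this change. It is a 1.1-fold higher number from compound 1 to compound 2 (0.04 log units; within the scatter), with 3-methylphenyl in place of 2-methylphenyl, and it stays within the scatter. Among the measured compounds shown here, that step relocates the methyl and does not remove it, and no compound without the methyl has a measured number yet, so the evidence is indirect. No size or direction beyond the scatter is therefore expected in this assay. The estimate is a 1.0-fold lower number from compound 2 to compound 3 (0.01 log units; within the scatter), a step that is expected to remain within the scatter. Compound 3 is expected at 0.18 h, with an estimated range of 0.1 h to 0.33 h.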

Compound 3, half-life: 0.217 h
The estimate for compound 3 lay 1.2-fold (0.08 log units) below the measured number; the range from low to high includes it.
By their numbers in this assay, from the lowest: compounds 1, 2 and 3 (each within the scatter of the next).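

In this assay the methyl can now be judged by its removal and not only by its relocation: hydrogen in place of methyl on an aromatic carbon gives a 1.2-fold higher number from compound 2 to compound 3 (0.07 log units; within the scatter) and, for the same kind of replacement starting from the 2-methylphenyl compound, a 1.3-fold higher number from compound 1 to compound 3 (0.11 log units; within the scatter) as well. Both steps stay within the scatter, as did the earlier move of the methyl, so among these three compounds neither the presence of a methyl on this ring nor its place separates one half-life from another. Nothing available explains these numbers or links them to any property of the methyl.

The compounds shown leave open whether a group larger or different in kind from methyl at this place on the six-membered aromatic ring, such as a methoxy group, a chlorine or a carboxylic acid, would move the half-life beyond the scatter. They also leave open whether a change away from this ring, such as a longer chain on the amide-type nitrogen, would do so.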